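A few compounds are considered here, and "the series" means these few. Any claim that something is new, unique, unknown or untested is made for them only; others in the source may bear on it.

Measured compounds:

Compound 1 `NCCCNc1cc(N2CCc3ccccc3C2)nc2ccccc12` — 8400 nM
Compound 2 `NCCNc1cc(N2CCCc3ccccc3C2)nc2ccc(C(F)(F)F)cc12` — 6700 nM
Compound 3 `Cc1ccc2nc(N3CCCc4ccc(F)cc4C3)cc(NCC(C)(C)N)c2c1` — 23000 nM

In an ADME assay on HEp-2 cells (Homo sapiens) for cytotoxicity, read by CCK-8 assay, with a stated time of 5 days (on this read-out lower numbers stand for higher toxicity in this test and higher numbers for lower toxicity in this test), compound 3 gives the highest number of the three, and its gaps to compound 1 and to compound 2 both lie beyond the scatter, so compound 3 is the least toxic of the measured set in this assay. Compound 1 and compound 2 stand close to one another on this read-out.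

The next compound, compound 4 `Cc1ccc2nc(N3CCCc4ccc(F)cc4C3)cc(NCCNC3COC3)c2c1`, is not yet measured. It differs from compound 3 in one place: ((oxetan-3-yl)amino)methyl in place of 1-amino-1-methylethyl on a saturated chain carbon bound to a nitrogen on an aromatic ring

Within the data shown here, no pair of measured compounds differs in just this way, so there is no measured step to lean on for this assay. The exchanged part sits far from the shared core, on the chain attached to the aromatic nitrogen, and the rest of the molecule is unchanged. Without a precedent, the step from compound 3 to compound 4 in this assay is expected to be small, most likely within the scatter, with a slight lean towards a somewhat lower number, that is a 1.3-fold lower number from compound 3 to compound 4 (0.11 log units; within the scatter). Compound 4 is therefore estimated at 18000 nM in this assay, with a range from 7000 nM to 45000 nM.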

Compound 4, half-maximal cytotoxic concentration: > 100000 nM
Compound 4 ended at the assay's limit (the forecaster's own chance of this, stated with the estimate: 15%); at least 5.5-fold (0.74 log units) between middle value and limit.
By their numbers in this assay, from the lowest: compounds 2 and 1 (each within the scatter of the next); then compound 3. At a limit, above all of these: compound 4.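

In this assay compound 4 sits at a limit of the assay, > 100000 nM, and this is a limit, not a number. The step reads an at least 4.3-fold higher number from compound 3 to compound 4 (0.63 log units; beyond the scatter), the first measured sign that a change on a saturated chain carbon bound to a nitrogen on an aromatic ring can move this read-out towards lower toxicity in this test. Only a lower bound on the step can be given, and the true size of the change remains unknown because compound 4 stands at the limit: the limit of > 100000 nM in this assay, at which 1 of the 4 values shown sits.

The single step leaves apart neither the loss of 1-amino-1-methylethyl nor the entry of ((oxetan-3-yl)amino)methyl, so the compounds shown do not tell whether the oxetan-3-yl ring itself matters, or whether a plain 2-aminoethyl chain, a 2-(methylamino)ethyl chain or a 2-(cyclobutylamino)ethyl chain on the core of compound 3 would give a similar result. Going by these compounds, whether the same exchange carries over to the cores of compound 1 and compound 2 also remains open.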